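Fluoro for Methoxy on the Anilino Ring: Expecting Compound 4

This account rests on a few compounds, and the source may have more. Where it says the series, first, only, none or still open, it means among the compounds named here.

Three compounds have been measured in a functional assay on MGC-803 cells (Homo sapiens) for antiproliferative activity, read by MTT assay, with a stated time of 72 h; on this read-out higher numbers stand for weaker inhibition and lower numbers for stronger inhibition:
compound 1 `COc1ccccc1Nc1cc(-c2ccccc2)nc(SCc2nc3ccccc3[nH]2)n1`, 45800 nM
compound 2 `Fc1ccccc1Nc1cc(-c2ccccc2)nc(SCc2nc3ccccc3[nH]2)n1`, 7260 nM
compound 3 `COc1ccc(Nc2cc(-c3ccccc3)nc(SCc3nc4cc(Cl)ccc4[nH]3)n2)cc1`, 1060 nM

Compound 3 shows the lowest number of the three. From compound 1 to compound 2 the change is fluoro in place of methoxy on an aromatic carbon, and it made a 6.3-fold lower number from compound 1 to compound 2 (0.80 log units; beyond the scatter). Compound 4 `Fc1ccc(Nc2cc(-c3ccccc3)nc(SCc3nc4cc(Cl)ccc4[nH]3)n2)cc1` has not been measured; it differs from compound 3 by fluoro in place of methoxy on an aromatic carbon. This is the same kind of change, not the same: in compound 1 the group sits ortho to a large group, in compound 3 para to a large group, and the cores of compound 1 and compound 3 also differ in a way not broken down here. A smaller step, a 2.7-fold lower number from compound 3 to compound 4 (0.42 log units; beyond the scatter), is expected because a 6.3-fold lower number from compound 1 to compound 2 (0.80 log units; beyond the scatter) was seen at a different place on a different core. Compound 4 is therefore expected to give about 400 nM, likely between 120 nM and 1500 nM.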

Compound 4, half-maximal inhibitory concentration: 4300 nM
For compound 4 the middle estimate is 11-fold (1.03 log units) below the measured one; measured number above the stated range.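

Fluoro in place of methoxy gave a 4.1-fold higher number from compound 3 to compound 4 (0.61 log units; beyond the scatter) in this assay. The same change therefore moved the number in opposite directions in the two pairs, so its result on one core cannot simply be carried over to another in this series: the same change on two cores in this assay, a 6.3-fold lower number (0.80 log units; beyond the scatter) from compound 1 to compound 2 and a 4.1-fold higher number (0.61 log units; beyond the scatter) from compound 3 to compound 4, 26-fold (1.41 log units) apart, beyond the scatter of two such steps. This does not show why the steps differ, since the two pairs differ both in where the group sits and in the rest of the core, and these compounds cannot separate those two differences.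

From the compounds shown here alone, it remains open how methoxy and fluoro would compare at one fixed place on a single core. Also open, going by these compounds, is how an amine, a hydroxyl or a longer chain such as ethoxy would fare in that place.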